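The source may report more compounds than this note shows. Statements on the series, on what has been measured and on what is new or still open speak of the compounds shown alone.

Compound 1 `CCC(C)(C)Cc1c[nH]c(CCc2ccc(-c3cccc(C)n3)cc2)n1` gives 6.3 nM in an in vitro assay on CHO cells for displacement of a labelled ligand from Bombesin receptor subtype-3 (Homo sapiens), read by scintillation counting, with a stated time of 2 h; a higher number here means a weaker inhibitor, a lower number a stronger inhibitor. Compound 2 `CCC(C)(C)Cc1c[nH]c(CCc2ccc(-c3cnccn3)cc2)n1` gives 51 nM.

On these two numbers compound 2 stands highest; its nearest neighbour is compound 1, the step being an 8.1-fold higher number from compound 1 to compound 2 (0.91 log units; beyond the scatter). Compound 3 `CCC(C)(C)Cc1c[nH]c(CCc2ccc(-c3cccnc3C(=O)O)cc2)n1` carries the change 2-carboxypyridin-3-yl in place of pyrazin-2-yl on an aromatic carbon at the position para to a large group. Among the measured compounds shown here, only the one measured step, a swap of the six-membered heteroaryl at the same place, bears on it, and it was modest. A step of similar size, either way, is expected; the estimate for compound 3 is 100 nM (range 20 nM to 600 nM), meaning a 2.0-fold higher number from compound 2 to compound 3 (0.29 log units; within the scatter).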

Compound 3, half-maximal inhibitory concentration: 560 nM
The estimate for compound 3 lay 5.6-fold (0.75 log units) below the measured number, and the stated range covers the measured number.
By their numbers in this assay, from the lowest: compound 1; then compound 2; then compound 3.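

Placing 2-carboxypyridin-3-yl on this aromatic carbon, para to a large group, gives an 11-fold higher number from compound 2 to compound 3 (1.04 log units; beyond the scatter) and an 89-fold higher number from compound 1 to compound 3 (1.95 log units; beyond the scatter). The earlier heteroaryl swap showed a modest cost, whereas this change, which brings in a hydrogen-bond donor that pyrazin-2-yl lacks, costs considerably more. No evidence available here bears on the reason for this rise.

The change alters the ring and adds the carboxyl group together, so their separate contributions remain unresolved. A methyl ester or primary amide in place of the carboxylic acid would address whether the acid itself matters.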